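Fluoro for hydrogen on the anilino ring of compound 1

A few compounds are considered here, and "the series" means these few. Any claim that something is new, unique, unknown or untested is made for them only; others in the source may bear on it.

Compound 1, `O=C1C=C(Nc2ccccc2)C(=O)c2c1nc1n2[C@H]2OC[C@@H](O)[C@H]2OC1`: 4970 nM
Compound 2, `O=C1C(Nc2ccc(Br)cc2)=CC(=O)c2c1nc1n2[C@H]2OC[C@@H](O)[C@H]2OC1`: 1980 nM
Compound 3, `CCc1ccc(NC2=CC(=O)c3c(nc4n3[C@H]3OC[C@@H](O)[C@H]3OC4)C2=O)cc1`: > 4000 nM

Of the compounds shown here, three sharing one core have been measured in a functional assay on ECa-109 cells for inhibition, with ECa-109 cell line (Homo sapiens) as the target, read by sulforhodamine B assay; a higher number here means a weaker inhibitor, a lower number a stronger inhibitor. Compound 1 gives 4970 nM, the higher of the two numbers reported, while compound 2 gives 1980 nM, a gap that lies beyond the usual scatter. For compound 3 the assay reports only a limit, > 4000 nM; this is the limit described as the limit of > 4000 nM in this assay, at which 1 of the 3 values shown sits. Within the data shown here, the one measured step, an at least 2.0-fold higher number from compound 2 to compound 3 (0.30 log units; that floor lies within the scatter), is itself bounded by that limit.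

Compound 4, `O=C1C=C(Nc2ccccc2F)C(=O)c2c1nc1n2[C@H]2OC[C@@H](O)[C@H]2OC1`, has not yet been measured. It differs from compound 1 by fluoro in place of hydrogen on an aromatic carbon, that is, phenyl becomes 2-fluorophenyl. Among the measured compounds shown here, no measured step concerns a change on this aromatic carbon; the only measured step compares bromo with ethyl elsewhere on the ring, so it bears on compound 4 only loosely. Compound 1 is therefore taken as the anchor, and a step of a 1.4-fold lower number from compound 1 to compound 4 (0.15 log units; within the scatter) is expected, which is within the scatter. Compound 4 is estimated to give 3500 nM, between 1500 nM and 8000 nM.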

Compound 4, half-maximal inhibitory concentration: 2760 nM
Compound 4: middle estimate off by 1.3-fold (0.10 log units), on the high side; the measured number falls inside the stated range.
By their numbers in this assay, from the lowest: compounds 2, 4 and 1 (each within the scatter of the next, the first and the last beyond it).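

In this assay the change to 2-fluorophenyl gives a 1.8-fold lower number from compound 1 to compound 4 (0.26 log units; within the scatter), so at this place, on an aromatic carbon ortho to a large group, fluoro in place of hydrogen cannot be told apart from the plain phenyl of compound 1. Among these compounds, this is the first reading at this ring carbon, since the earlier compounds carried their changes, bromo and ethyl, elsewhere on the anilino ring, and it shows that a single fluoro here leaves the number within the usual scatter of compound 1. Nothing measured among these compounds accounts for the size of this step, and it gives no ground for ascribing any property to the fluoro group.

From the compounds shown here alone, what would happen at this same carbon with chloro, methoxy or an amine stays open, so it is not known whether any group here can move the number beyond the scatter. Also open, going by these compounds, is how fluoro would read on the ring carbon that carries bromo in compound 2, or how a carboxylic acid or a longer chain would read on either carbon.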